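A few compounds are considered here, and "the series" means these few. Any claim that something is new, unique, unknown or untested is made for them only; others in the source may bear on it.

Measured in an ADME assay (liver) for metabolic stability, with Liver microsome (Homo sapiens) as the target, read by LC-MS, using microsomes and NADPH, with a stated time of 5 min, at 37 degrees C; on this read-out lower numbers stand for slow clearance and higher numbers for fast clearance:
Compound 1 `CCn1c([C@@H](C)NS(=O)(=O)c2ccc(CC(C)C)cc2)nc2ccc(C(F)(F)F)cc21`: > 100 mL.min-1.g-1, a limit of the assay
Compound 2 `CCn1c([C@@H](C)NS(=O)(=O)c2cn(C)nc2C)nc2ccc(C(F)(F)F)cc21`: 28 mL.min-1.g-1

Among the measured compounds shown here, compound 2 holds the only actual number in this assay so far, and the one other result is a limit. Compound 3 `CCCn1ncc(S(=O)(=O)N[C@H](C)c2nc3ccc(C(F)(F)F)cc3n2CC)c1C` differs from compound 2 in one place, on a sulfonyl sulfur: 5-methyl-1-propyl-1H-pyrazol-4-yl in place of 1,3-dimethyl-1H-pyrazol-4-yl on a sulfonyl sulfur. For the measured compounds named here, the single measured step that bears on this change is an at least 3.5-fold lower number from compound 1 to compound 2 (0.55 log units; beyond the scatter), where 1,3-dimethyl-1H-pyrazol-4-yl replaced 4-isobutylphenyl. Its size is only a bound, and it rests on (the limit of > 100 mL.min-1.g-1 in this assay, at which 1 of the 2 values shown sits). The entering 5-methyl-1-propyl-1H-pyrazol-4-yl keeps the five-membered aromatic ring but is larger, so a small part of that step might be expected to return, with the number moving upward. The expected change is a 1.6-fold higher number from compound 2 to compound 3 (0.21 log units; within the scatter). For compound 3 the estimated value is 45 mL.min-1.g-1, with an expected range from 22 mL.min-1.g-1 to 95 mL.min-1.g-1.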

Compound 3, intrinsic clearance in microsomes: > 100 mL.min-1.g-1
Compound 3 ended at the assay's limit; the forecaster's own chance of this, stated with the estimate: 10%; middle value at least 2.2-fold (0.34 log units) from the limit.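

In this assay, the sulfonyl sulfur position proves sensitive even when the five-membered aromatic ring is kept: 5-methyl-1-propyl-1H-pyrazol-4-yl in place of 1,3-dimethyl-1H-pyrazol-4-yl gives an at least 3.5-fold higher number from compound 2 to compound 3 (0.55 log units; beyond the scatter). The ring alone therefore does not secure the lower number seen for compound 2, and what is attached to it matters. The size of this step is only a bound, and the step between compound 1 and compound 3 cannot be read at all, because of this: the limit of > 100 mL.min-1.g-1 in this assay, at which 2 of the 3 values shown sit.

The compounds shown leave open how far compound 3 lies past the limit, and whether the propyl chain or the changed placing of the methyl group accounts for the rise. Nor do they show where the number would fall with an ethyl chain, or a chain carrying a hydroxyl group, in place of the propyl chain.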